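The source may report more compounds than this note shows. Statements on the series, on what has been measured and on what is new or still open speak of the compounds shown alone.

Working notes on the series. Compound 3 `COc1ccc(-c2cnc3nc(N)nc(N4CCN(C(=O)Nc5ccc(F)cc5)CC4)c3n2)cc1OC` sits at the low end of the three numbers in a functional assay on cells (T-cell, Homo sapiens) for inhibition; on this read-out lower numbers stand for stronger inhibition and higher numbers for weaker inhibition: compound 3 gives 7 nM, compound 1 `COc1ccc(-c2cnc3nc(N)nc(N4CCN(c5ccc(C)cc5)CC4)c3n2)cc1OC` gives 300 nM and compound 2 `COc1ccc(-c2cnc3nc(N)nc(N4CCN(c5cc(Cl)cc(Cl)c5)CC4)c3n2)cc1OC` gives 3400 nM. The steps into compound 3 are both large, a 43-fold lower number from compound 1 to compound 3 (1.63 log units; beyond the scatter) and a 490-fold lower number from compound 2 to compound 3 (2.69 log units; beyond the scatter), and both exchange a phenyl group on the amine nitrogen in the ring for a carbamoyl group there. Between the two phenyl groups alone, an 11-fold higher number from compound 1 to compound 2 (1.05 log units; beyond the scatter) shows that a change on that aryl ring by itself can move the number far.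

Compound 4 `COc1ccc(-c2cnc3nc(N)nc(N4CCN(C(=O)Nc5cccc(C)c5)CC4)c3n2)cc1OC` keeps the carbamoyl and changes only the aryl part: 3-methylphenyl in place of 4-fluorophenyl on an amide-type nitrogen. Going by the values given here, no measured step exchanges one aryl for another on the amide-type nitrogen, so the only guide is the aryl-to-aryl step from compound 1 to compound 2 on the other nitrogen, and that step is the only one of its kind here. A change on the order of that step, or none beyond the scatter, is both possible; a moderate rise in number is expected as a 2.1-fold higher number from compound 3 to compound 4 (0.33 log units; beyond the scatter). Compound 4 is therefore estimated at 15 nM, with a range from 4 nM to 60 nM.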

Compound 4, half-maximal inhibitory concentration: 7 nM
Estimate against measurement, compound 4: 2.1-fold (0.33 log units) above; the measured number falls inside the stated range.
By their numbers in this assay, from the lowest: compounds 3 and 4 (each within the scatter of the next); then compound 1; then compound 2.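

In this assay, going by these compounds alone, the exchange of 4-fluorophenyl for 3-methylphenyl on the amide-type nitrogen gives no change at the digits printed from compound 3 to compound 4 (within the scatter) and so offers the first aryl-for-aryl reading on that nitrogen, where the number stays put, whereas the aryl exchange on the amine nitrogen in the ring gives an 11-fold higher number from compound 1 to compound 2 (1.05 log units; beyond the scatter) as its reading. The large gap between the carbamoyl and aryl compounds now holds for a second carbamoyl compound, with a 43-fold lower number from compound 1 to compound 4 (1.63 log units; beyond the scatter) and a 490-fold lower number from compound 2 to compound 4 (2.69 log units; beyond the scatter) as its steps, so it no longer rests on compound 3 alone. Nothing at hand explains why the two aryl groups read alike on the amide-type nitrogen or why the carbamoyl compounds stand so far from compound 1 and compound 2.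

The compounds shown leave open whether the number holds with a cyclohexyl or pyridyl group on the amide-type nitrogen. They also leave open whether that nitrogen is needed at all, which a benzoyl group in place of the (4-fluorophenyl)carbamoyl on the amine nitrogen in the ring would test.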